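The compounds below may be only part of what the source reports. "The series", "measured", "known", "first", "only" and "open" are said of these compounds alone.

Three compounds with measured exposure frame this step. In an ADME assay on the whole organism (Rattus norvegicus, strain Fischer 344) for pharmacokinetics, at a dose of 3 mg/kg by the oral route (a lower number here means less compound in the circulation, a higher number more compound in the circulation at the dose given), compound 1 `Cc1cc(N2CCC[C@H](COCc3nc(C)no3)C2)c2c(N)c(C(N)=O)sc2n1` gives 451 nM, compound 2 `COC[C@H]1CCCN(c2ccnc3sc(C(N)=O)c(N)c23)C1` gives 251 nM and compound 3 `NC(=O)c1sc2nccc(N3CCC[C@H](COCCO)C3)c2c1N` gives 326 nM. These three values lie within the scatter of one another, so compound 3 cannot be separated from either neighbour.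

The next compound is compound 4 `Cc1noc(COC[C@H]2CCCN(c3ccnc4sc(C(N)=O)c(N)c34)C2)n1`, and its difference from compound 3 is 3-methyl-1,2,4-oxadiazol-5-yl in place of hydroxymethyl on a saturated chain carbon bound to an oxygen on a saturated carbon. In words, 3-methyl-1,2,4-oxadiazol-5-yl replaces hydroxymethyl on a saturated chain carbon bound to an oxygen on a saturated carbon.

Within the data shown here, the one measured step at this place is a 1.3-fold higher number from compound 2 to compound 3 (0.11 log units; within the scatter). It is a different replacement and stays within the scatter, so it offers no sign that this place moves this assay much. Among the measured compounds shown here, no measured pair shows the exact change in question. For the measured compounds named here, compound 1 is the only measured compound carrying 3-methyl-1,2,4-oxadiazol-5-yl, and its 451 nM remains within the scatter of compound 3 at 326 nM.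

No shift beyond the scatter is therefore expected, in either direction, though this rests on thin evidence. The expected step is a 1.1-fold higher number from compound 3 to compound 4 (0.04 log units; within the scatter). For compound 4 the estimated value is 360 nM, with an expected range of 160 nM to 800 nM.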

Compound 4, maximal plasma concentration: 393 nM
Estimate against measurement, compound 4: 1.1-fold (0.04 log units) below; measured number inside the range.
By their numbers in this assay, from the lowest: compounds 2, 3, 4 and 1 (each within the scatter of the next).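

In this assay, the exact exchange now has its own reading, a 1.2-fold higher number from compound 3 to compound 4 (0.08 log units; within the scatter), so a group of 6 heavy atoms with one five-membered aromatic ring and a group of 2 heavy atoms with no ring cannot be told apart at this place. The same group set against the hydrogen of compound 2 gives a 1.6-fold higher number from compound 2 to compound 4 (0.19 log units; within the scatter), so hydrogen, hydroxymethyl and 3-methyl-1,2,4-oxadiazol-5-yl on a saturated chain carbon bound to an oxygen on a saturated carbon all stay within the scatter of one another in these three compounds. A second place also has a first reading: hydrogen in place of methyl on an aromatic carbon gives a 1.1-fold lower number from compound 1 to compound 4 (0.06 log units; within the scatter), again with no separation in this assay.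

Whether an amine or a carboxylic acid at this place would move the number beyond the scatter remains open, since all the groups shown here stay within it. No supporting measurement bears on these results, so nothing can be said about what lies behind them.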